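The compounds below may be only part of what the source reports. "The series", "measured", "known", "first", "only" and "open" are said of these compounds alone.

Compound 1 `Cc1nc(NCCNC(=O)C2CC2)nc2ccc(NC(=O)/C=C/c3ccc(OC(F)(F)F)cc3)cc12` gives 38%
Compound 2 `Cc1nc(N2CCC(N3CCNC3=O)CC2)nc2ccc(NC(=O)/C=C/c3ccc(OC(F)(F)F)cc3)cc12` gives 89%
Compound 3 `Cc1nc(NCCCNS(C)(=O)=O)nc2ccc(NC(=O)/C=C/c3ccc(OC(F)(F)F)cc3)cc12` gives 58%

All three compounds share the same core and differ only in the group attached to one aromatic carbon. In an ADME assay on microsomes from liver (Mus musculus) for metabolic stability, with a stated time of 30 min (on this read-out higher numbers stand for a more stable compound and lower numbers for a less stable compound), compound 2 gives 89%, the highest of the three numbers; both steps leading to it are beyond the scatter, namely a number 51 percentage points higher from compound 1 to compound 2 (beyond the scatter) and, read the other way, a number 31 percentage points lower from compound 2 to compound 3 (beyond the scatter). The remaining step, a number 20 percentage points higher from compound 1 to compound 3 (beyond the scatter), is also beyond the scatter.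

Compound 4 `Cc1nc(N2CCC(N3CCN(C)C3=O)CC2)nc2ccc(NC(=O)/C=C/c3ccc(OC(F)(F)F)cc3)cc12` is compound 2 with a single change: methyl in place of hydrogen on an amide-type nitrogen in a ring. None of the three measured steps covers a change of this kind. Each of them swaps the whole side chain on the aromatic carbon, whereas here the side chain stays and only a hydrogen on the amide-type nitrogen in the five-membered non-aromatic ring is exchanged for a methyl. The measured steps therefore give no direct guide; they show only that large movements in this assay come from changing the entire side chain. For a change of one carbon, a step within the scatter or a small decrease is expected, so the step of a number 9 percentage points lower from compound 2 to compound 4 (within the scatter) is the estimate. Compound 4 is accordingly expected to give 80%, with a range from 60% to 94%.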

Compound 4, percent of the compound remaining: 94%
Beside the measured number, compound 4's estimate is 14 percentage points below it, within the range that was stated.
By their numbers in this assay, from the lowest: compound 1; then compound 3; then compounds 2 and 4 (each within the scatter of the next).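

In this assay, putting a methyl in place of the amide hydrogen on the five-membered ring gives a step that reads a number 5 percentage points higher from compound 2 to compound 4 (within the scatter) and lies within the usual scatter. Among these compounds, the earlier compounds differ by swapping the whole side chain, whereas this pair offers the first look at a change inside it, and compound 2 and compound 4 cannot be told apart on this read-out. The amide-type nitrogen, two ring bonds from the ring atom that bears a large group, can therefore carry this single carbon with no readable loss of the high number, although nothing available explains why that number holds.

On these data alone, this pair speaks only for hydrogen and methyl, so it remains open whether a larger group on the same nitrogen, such as an ethyl, an acetyl or a longer chain ending in an amine or a carboxylic acid, would also leave the number unchanged. As far as these compounds go, it is also open how far the tolerance of this one nitrogen extends to other parts of the 2-oxoimidazolidin-1-yl ring, such as a methyl on one of its ring carbons.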